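This account rests on a few compounds, and the source may have more. Where it says the series, first, only, none or still open, it means among the compounds named here.

Measured so far in a functional assay on HT-1080 cells (Homo sapiens) for antiproliferative activity, read by sulforhodamine B assay, with a stated time of 48 h; on this read-out higher numbers stand for weaker inhibition and lower numbers for stronger inhibition:
compound 1, `CC(C)C(=O)Nc1cccc(S(=O)(=O)Oc2ccccc2C(C)C)c1`, 16000 nM
compound 2, `CC(C)c1ccccc1OS(=O)(=O)c1cccc(NC(=O)C(C)(C)C)c1`, 11000 nM
compound 3, `CCC(=O)Nc1ccc(S(=O)(=O)Oc2ccccc2C(C)C)cc1`, 2100 nM

Compound 2 differs from compound 1 by methyl in place of hydrogen on a saturated chain carbon bound to a carbonyl carbon and two saturated chain carbons; this gave a 1.5-fold lower number from compound 1 to compound 2 (0.16 log units; within the scatter). Compound 3 has the lowest number of the three, and its difference from the core of compound 1 is not broken down here. Compound 4, `CCCC(=O)Nc1ccc(S(=O)(=O)Oc2ccccc2C(C)C)cc1`, is not yet measured. It differs from compound 3 by methyl in place of hydrogen on a saturated chain carbon, two bonds along the chain from a carbonyl carbon. This is the same kind of change as that from compound 1 to compound 2, though the place differs: in compound 2 the methyl enters on a saturated chain carbon bound to a carbonyl carbon and two saturated chain carbons, in compound 4 on a saturated chain carbon, two bonds along the chain from a carbonyl carbon. Resting on the earlier step, a 1.5-fold lower number from compound 1 to compound 2 (0.16 log units; within the scatter), which stayed within the scatter, a similarly small step is expected here: a 1.3-fold lower number from compound 3 to compound 4 (0.12 log units; within the scatter). In this assay compound 4 is thus expected to give 1600 nM, with a plausible range from 700 nM to 4500 nM.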

Compound 4, half-maximal inhibitory concentration: 950 nM
The estimate for compound 4 lay 1.7-fold (0.23 log units) above the measured number; low and high end bracket the measured number.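

Methyl in place of hydrogen, on a saturated chain carbon two bonds along the chain from a carbonyl carbon, gave a 2.2-fold lower number from compound 3 to compound 4 (0.34 log units; beyond the scatter) in this assay. The step on this core does not differ from the earlier one on the other core: the same change on two cores in this assay, a 1.5-fold lower number (0.16 log units; within the scatter) from compound 1 to compound 2 and a 2.2-fold lower number (0.34 log units; beyond the scatter) from compound 3 to compound 4, 1.5-fold (0.18 log units) apart, within the scatter of two such steps. The two steps fit one common size, but they rest on a single pair per core with the methyl in different places, and the earlier step alone does not establish an effect, so no general rule for the series follows.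

Still open, from the compounds shown here alone, is whether a longer chain than propylcarbonyl lowers the number further. Also open, going by these compounds, is what an amine or a carboxylic acid in place of the methyl would give.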